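The source may report more compounds than this note shows. Statements on the series, on what has been measured and on what is new or still open speak of the compounds shown alone.

In an ADME assay on microsomes from liver (Mus musculus) for metabolic stability, read by HPLC, with a stated time of 30 min (on this read-out higher numbers stand for a more stable compound and lower numbers for a less stable compound), compound 1 `COc1ccc(NC(=O)C(=O)c2c[nH]c3cc(Cl)ccc23)cc1` gives 87.3% and compound 2 `COc1ccc(NC(=O)C(=O)c2c[nH]c3cc(F)ccc23)cc1` gives 74.6% (the lower of the two numbers). Compound 3 `COc1ccc(NC(=O)C(=O)c2c[nH]c3cc(C#N)ccc23)cc1` has not yet been measured. It differs from compound 2 by cyano in place of fluoro on an aromatic carbon. Within the data shown here, only one measured step bears on this change: fluoro in place of chloro on an aromatic carbon, with a number 12.7 percentage points lower from compound 1 to compound 2 (beyond the scatter) as its size. That step shows that exchanging a group on this carbon can move the number by a modest amount. Among the measured compounds shown here, no measured compound carries cyano, however, so the step gives a rough scale and does not settle the direction. A step no larger than that one is therefore expected in this assay with only a slight lean upward, and it may well stay within the scatter. The estimate amounts to a number 4.4 percentage points higher from compound 2 to compound 3 (within the scatter) as the expected step. Compound 3 is expected at 79% within an estimated range from 62% to 93% in this read-out.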

Compound 3, percent of the compound remaining: 87.5%
Compound 3: middle estimate off by 8.5 percentage points, on the low side; low and high end bracket the measured number.
By their numbers in this assay, from the lowest: compound 2; then compounds 1 and 3 (each within the scatter of the next).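

In this assay the exchange of fluoro for cyano on this carbon gives a number 12.9 percentage points higher from compound 2 to compound 3 (beyond the scatter) and thus shows that a change here can raise the number as well as lower it, which the step from chloro to fluoro alone did not show. The exchange of chloro for cyano gives a number 0.2 percentage points higher from compound 1 to compound 3 (within the scatter) and so places these two groups level in this assay, even though cyano enters with one more heavy atom than fluoro and brings a triple bond and a hydrogen-bond acceptor. Of the three groups on this carbon, fluoro alone stands apart on the low side, and nothing measured here offers a reason for that.

On these data alone, whether an amine, a carboxylic acid or a simple methyl on the same carbon would fall with fluoro or with chloro and cyano remains open. So does the question of whether fluoro would stand apart in the same way if the methoxy group of the shared core gave way to a hydroxyl or a longer alkoxy chain.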